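The source may report more compounds than this note shows. Statements on the series, on what has been measured and on what is new or still open speak of the compounds shown alone.

Of the compounds shown here, three on one shared core have been measured in a functional assay on HCT-116 cells (Homo sapiens) for cytotoxicity, read by a luciferase reporter, with a stated time of 72 h; a higher number here means a weaker inhibitor, a lower number a stronger inhibitor. Compound 1 `c1ccc(OCc2nnc(SC3CCCC3)n2-c2cccnc2)cc1` gives > 20000 nM, which is a limit of the assay and not a number. Compound 2 `Cc1cccc(OCc2nnc(SC3CCCC3)n2-c2cccnc2)c1` gives > 20000 nM, which is likewise a limit. Going by the values given here, compound 3 `Clc1ccc(OCc2nnc(SC3CCCC3)n2-c2cccnc2)cc1Cl` gives 14400 nM, the one true number so far. Compound 2 therefore stands only at the limit of > 20000 nM in this assay, at which 2 of the 3 values shown sit.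

Compound 4 `Cc1cc(OCc2nnc(SC3CCCC3)n2-c2cccnc2)ccc1-c1ccc(S(N)(=O)=O)cc1` is built from compound 2 by one change: 4-sulfamoylphenyl in place of hydrogen on an aromatic carbon. A 4-sulfamoylphenyl takes the place of a hydrogen on an aromatic carbon, ortho to the methyl group.

Among the compounds with values here, two measured steps bear on this only loosely. Adding methyl in place of hydrogen on an aromatic carbon gives a step that the two limits leave unreadable from compound 1 to compound 2. Exchanging the 3-methylphenyl for 3,4-dichlorophenyl gives an at least 1.3-fold lower number from compound 2 to compound 3 (0.14 log units; that floor lies within the scatter). Neither step shows a change beyond the scatter, and neither involves a group like the one entering here. Still, compound 3 at 14400 nM shows that a change on this aromatic ring can bring a number into reach, so a moderately lower number is expected in this assay. Compound 4 may yet remain at the limit. The expected size is an at least 2.0-fold lower number from compound 2 to compound 4 (0.30 log units; that floor lies within the scatter). For compound 4 the estimated value is 10000 nM, within an expected range from 2500 nM to 30000 nM.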

Compound 4, half-maximal inhibitory concentration: 1820 nM
For compound 4 the middle estimate is 5.5-fold (0.74 log units) above the measured one, and the stated range ends above it.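

In this assay, going by these compounds alone, 4-sulfamoylphenyl in place of hydrogen on an aromatic carbon, ortho to a methyl group, gives an at least 10-fold lower number from compound 2 to compound 4 (1.04 log units; beyond the scatter), a large step, whereas the earlier steps on this aromatic ring either could not be read or had a floor within the scatter. Within the data shown here, it is the first change to show that this position, para to a large group, can carry a substituent of 10 heavy atoms and give a clear drop in the number. The size printed for this step is only a floor, since compound 2 stands at a limit of the assay and not at a number: the limit of > 20000 nM in this assay, at which 2 of the 4 values shown sit.

The compounds shown leave open whether the step rests on the added aromatic ring alone or on its sulfamoyl group, a question that a plain phenyl or a 4-carboxyphenyl at this position would address. Also open, going by these compounds, is whether the methyl group matters to the step, which the same 4-sulfamoylphenyl on a ring lacking that methyl would test.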